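The source may hold more compounds than are shown below. What is called first, only, known or untested is meant among the compounds shown, and "the series" means these compounds.

Working notes on a small series tested in an ADME assay on Vero cells (Chlorocebus sabaeus) for cytotoxicity, read by WST assay, tested at 50 ug/mL; a lower number here means a stronger effect, a higher number a weaker effect of the compound at the concentration tested. Compound 1 `COC(=O)[C@H](CO)NC(=O)/C=C/c1ccc(F)cc1` returned "not determined" (no result reported) in this assay. Compound 2 `COC(=O)[C@H](CO)NC(=O)/C=C/c1ccc(OC)cc1` gives 100% in this assay. Compound 3 `COC(=O)c1coc(/C=C/c2ccc(OC)cc2)n1` gives 99.6% in this assay; its number and that of compound 2 lie within the usual scatter of each other, so the two stand together, and compound 1 supplies no number to place it against. Compound 4 `COC(=O)c1coc(/C=C/c2ccccc2)n1` has not yet been measured in this assay. Compound 4 differs from compound 3 by hydrogen in place of methoxy on an aromatic carbon. Within the data shown here, no step between measured compounds covers this change. Given compound 3 at 99.6%, the expected step is a number 1.6 percentage points lower from compound 3 to compound 4 (within the scatter) in this assay, none beyond the scatter. Compound 4 is estimated at 98% in this assay, between 86% and 104%.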

Compound 4, a percentage reported as activity, at one concentration (the size of the read-out at that concentration, not a potency): 99.6%
The estimate for compound 4 lay 1.6 percentage points below the measured number; low and high end bracket the measured number.
By their numbers in this assay, from the lowest: compounds 3, 4 and 2 (each within the scatter of the next).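

Hydrogen in place of methoxy on the six-membered aromatic ring, para to a large group, gives no change at the digits printed from compound 3 to compound 4 (within the scatter) in this assay. Among these compounds, this is the first reading of this change, and at this position the methoxy can go without any shift in the read-out beyond the scatter. No available data bear on the reason for this.

As far as these compounds go, whether an amine, a carboxylic acid or a longer alkoxy chain at this position would move the number remains open. None of the compounds shown yet marks a change here that lowers the read-out beyond the scatter.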